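Cyclohexyl Replaces Phenyl on the Amine Nitrogen

The source may report more compounds than this note shows. Statements on the series, on what has been measured and on what is new or still open speak of the compounds shown alone.

compound 1 `O=c1cc(Nc2ccccc2)cc(-c2ccccc2)o1`: 0.13 uM
compound 2 `COc1ccccc1Nc1cc(-c2ccccc2)oc(=O)c1`: 0.35 uM

In a functional assay on KB cells (Homo sapiens) for cytotoxicity, read by MTT assay, with a stated time of 72 h (a higher number here means that more compound is needed for the effect, a lower number that less compound is needed), compound 1 gives 0.13 uM, the lowest of the two numbers; compound 2 lies one step away, a 2.7-fold higher number from compound 1 to compound 2 (0.43 log units; beyond the scatter). Compound 3 `O=c1cc(NC2CCCCC2)cc(-c2ccccc2)o1` differs from compound 1 by cyclohexyl in place of phenyl on a nitrogen on an aromatic ring. Going by the values given here, the single measured step alters a different part of the molecule, a substituent on the aryl ring rather than the ring itself, so it bears little on this change and no direct guide exists. Compound 3 is therefore expected, with wide uncertainty, to give 0.5 uM within 0.1 uM to 3 uM, which would be estimated as a 3.8-fold higher number from compound 1 to compound 3 (0.59 log units; beyond the scatter).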

Compound 3, concentration for half-maximal effect: 16 uM
Estimate against measurement, compound 3: 32-fold (1.51 log units) below, outside the stated range (above it).
By their numbers in this assay, from the lowest: compound 1; then compound 2; then compound 3.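

With the same number of heavy atoms entering as leaving, the aromatic ring on the nitrogen gives way to a non-aromatic one, and the number in this assay rises sharply (a 120-fold higher number from compound 1 to compound 3 (2.09 log units; beyond the scatter)). This large step shows that this position tolerates the exchange of phenyl for cyclohexyl far less well than the methoxy substitution on the phenyl ring (a 2.7-fold higher number from compound 1 to compound 2 (0.43 log units; beyond the scatter)) had suggested. Nothing available explains the size of this step.

The compounds shown leave open how a pyridyl ring, a benzyl group or a short alkyl chain on the same nitrogen would read in this assay. They also leave open whether a hydroxyl or a halogen on the phenyl ring would change the number.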